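Furan-to-thiophene swap on a nucleoside series at the limit

The source may hold more compounds than are shown below. What is called first, only, known or untested is meant among the compounds shown, and "the series" means these compounds.

Three analogues share a ribose-bearing bicyclic core that carries a five-membered heteroaryl group. Compound 1 `Nc1nc2c(c(-c3cccs3)cn2[C@@H]2O[C@H](CO)[C@@H](O)[C@H]2O)c(=O)[nH]1` bears thiophen-2-yl. Compound 3 `Nc1nc2c(c(-c3ccoc3)cn2[C@@H]2O[C@H](CO)[C@@H](O)[C@H]2O)c(=O)[nH]1` bears furan-3-yl on the same core. Compound 2 `CSc1ncnc2c1c(-c1ccoc1)cn2[C@@H]1O[C@H](CO)[C@@H](O)[C@H]1O` carries furan-3-yl on a core that differs from that of compound 3, and the difference between the two cores is not broken down here. Compound 4 `CSc1ncnc2c1c(-c1cccs1)cn2[C@@H]1O[C@H](CO)[C@@H](O)[C@H]1O`, not yet measured, pairs the core of compound 2 with thiophen-2-yl.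

In a functional assay on HepG2 cells (Homo sapiens) for antiproliferative activity, read by XTT assay, with a stated time of 72 h (on this read-out lower numbers stand for stronger inhibition and higher numbers for weaker inhibition), compound 3 gives only a limit, > 20000 nM. In this assay compound 1 likewise gives only a limit, > 20000 nM. For compound 2 this assay also reports only a limit, > 15000 nM. The values cluster at limits: the limit of > 20000 nM in this assay, at which 2 of the 3 values shown sit, while (the limit of > 15000 nM in this assay, at which 1 of the 3 values shown sits).

The change thiophen-2-yl in place of furan-3-yl on an aromatic carbon is measured as a step that the two limits leave unreadable from compound 3 to compound 1. The same change, (thiophen-2-yl in place of furan-3-yl on an aromatic carbon), is made from compound 2 to compound 4. The measured step between compound 3 and compound 1 sits between two limits, and compound 2 itself starts at a limit, so no readable movement is available to carry over. On that rests the expected step that the limit leaves unreadable from compound 2 to compound 4, essentially none. Compound 4 is therefore expected to give about 20000 nM in this assay, within an estimated range of 8000 nM to 50000 nM, and most likely to be reported again only as a limit.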

Compound 4, half-maximal inhibitory concentration: > 20000 nM
Compound 4: no number, only a limit (the forecaster's own chance of this, stated with the estimate: 85%); the middle value lies on the limit itself.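

Among these compounds, compound 2 and compound 4 are both reported only as limits in this assay, and the step between them cannot be read, any more than the one between compound 3 and compound 1. The compounds shown leave open whether thiophen-2-yl in place of furan-3-yl changes antiproliferative activity at all on either core, and whether any of the four compounds has a measurable potency.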